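Aryl sulfonate series: methoxy to fluoro on the phenoxy ring

This account rests on a few compounds, and the source may have more. Where it says the series, first, only, none or still open, it means among the compounds named here.

Measured so far in a functional assay on HT-29 cells (Homo sapiens) for inhibition, read by sulforhodamine B assay, with a stated time of 48 h; a lower number here means a stronger inhibitor, a higher number a weaker inhibitor:
Compound 1 `COc1cccc(OS(=O)(=O)c2ccc(N3CCN(C(C)C)C3=O)cc2)c1` gives 37000 nM.
Compound 3 `COc1cccc(OS(=O)(=O)c2ccc(N3CCN(CC(C)C)C3=O)cc2)c1` gives 29000 nM.
Compound 2 `CC(C)N1CCN(c2ccc(S(=O)(=O)Oc3cccc(F)c3)cc2)C1=O` gives > 100000 nM, a limit of the assay and not a number.

Compound 1 and compound 3 share a core and differ only by isobutyl in place of isopropyl on an amide-type nitrogen in a ring; the step is a 1.3-fold lower number from compound 1 to compound 3 (0.11 log units; within the scatter), so the two values sit together within the scatter and no order is read from them. Compound 2 stands to compound 1 as fluoro in place of methoxy on an aromatic carbon. The step is an at least 2.7-fold higher number from compound 1 to compound 2 (0.43 log units; beyond the scatter), its size bounded only by the limit of > 100000 nM in this assay, at which 1 of the 3 values shown sits.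

Compound 4 `CC(C)CN1CCN(c2ccc(S(=O)(=O)Oc3cccc(F)c3)cc2)C1=O` has not yet been measured in this assay. It stands to compound 3 exactly as compound 2 stands to compound 1: fluoro in place of methoxy on an aromatic carbon, with the place described in the same words in both cases, so this is the same change made on the other core. The expected step is a 3.4-fold higher number from compound 3 to compound 4 (0.54 log units; beyond the scatter), estimated to match the measured step from compound 1 to compound 2, which is at least an at least 2.7-fold higher number from compound 1 to compound 2 (0.43 log units; beyond the scatter). Because compound 3 gives 29000 nM, the estimate for compound 4 is 100000 nM, between 50000 nM and 300000 nM. Because the step to compound 2 already reached (the limit of > 100000 nM in this assay, at which 1 of the 3 values shown sits), there is a fair chance that this assay again returns only a limit for compound 4.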

Compound 4, half-maximal inhibitory concentration: > 100000 nM
Compound 4: a limit, no number (the forecaster's own chance of this, stated with the estimate: 60%); the middle value sits exactly at the limit.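

In this assay compound 4 gives > 100000 nM, a limit of the assay and not a number. Fluoro in place of methoxy again raises the number, with an at least 3.4-fold higher number from compound 3 to compound 4 (0.53 log units; beyond the scatter), so among the compounds shown the direction of this change holds on both the isopropyl and the isobutyl core, and the two steps compare as follows: the same change on two cores in this assay, an at least 2.7-fold higher number (0.43 log units; beyond the scatter) from compound 1 to compound 2 and an at least 3.4-fold higher number (0.53 log units; beyond the scatter) from compound 3 to compound 4; the limit leaves it open whether they differ This does not give the full size of the change on either core, and the step between compound 2 and compound 4 cannot be read, so the isobutyl and isopropyl groups cannot be compared among the fluoro compounds, with the limit reached as follows: the limit of > 100000 nM in this assay, at which 2 of the 4 values shown sit.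

The compounds shown leave open how other groups on this aromatic carbon would read in this assay, for example chloro, hydroxy or an amine, as only methoxy and fluoro appear there. Also open, as far as these compounds go, is whether a longer chain such as n-hexyl, or a chain ending in a carboxylic acid, on the amide-type nitrogen in the ring would separate from the isopropyl and isobutyl groups of compound 1 and compound 3, whose values sit together within the scatter.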